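Pyridinyl to Phenyl on the Carbonyl: Expected Effect

The source may report more compounds than this note shows. Statements on the series, on what has been measured and on what is new or still open speak of the compounds shown alone.

Compound 1, `COc1cc2nc(N3CCN(C(=O)c4ccc[nH]4)[C@H]4CCCC[C@H]43)nc(N)c2cc1OC`: 7.33
Compound 2, `COc1cc2nc(N3CCN(C(=O)c4ccccn4)[C@H]4CCCC[C@H]43)nc(N)c2cc1OC`: 7.12

In a functional assay on thoracic aorta for antagonist activity at Alpha-1D adrenergic receptor (Rattus norvegicus) (a lower number here means a less potent compound, a higher number a more potent compound, by a factor of ten per unit of this negative logarithm), compound 2 gives 7.12, the lowest of the two numbers, with compound 1 a distance away that lies within the scatter. For the measured compounds named here, the one measured step, a number 0.21 log units lower from compound 1 to compound 2 (within the scatter), stayed within the scatter. Compound 3 `COc1cc2nc(N3CCN(C(=O)c4ccccc4)[C@H]4CCCC[C@H]43)nc(N)c2cc1OC` differs from compound 2 by phenyl in place of pyridin-2-yl on a carbonyl carbon. This exchange is not the one that was measured, so the measured step bears on it only loosely; with the two known values so close, for compound 3 no step beyond the scatter is expected, a number 0.02 log units lower from compound 2 to compound 3 (within the scatter). Compound 3 is estimated at 7.1, between 6.6 and 7.6.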

Compound 3, negative logarithm of the antagonist equilibrium constant: 7.76
Beside the measured number, compound 3's estimate is 0.66 log units below it; measured number outside the range, above it.
By their numbers in this assay, from the lowest: compounds 2 and 1 (each within the scatter of the next); then compound 3.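

In this assay, the ring on this carbonyl carbon proves to matter: phenyl gives a number 0.64 log units higher from compound 2 to compound 3 (beyond the scatter) and a number 0.43 log units higher from compound 1 to compound 3 (beyond the scatter) against the two nitrogen-bearing rings. For the compounds shown here, the earlier pair, pyridin-2-yl and 1H-pyrrol-2-yl, sat within the scatter of each other, so only this all-carbon ring separates from them. No measurement shown here explains the gain. Open, from the compounds shown here alone, is whether pyridin-3-yl, with its nitrogen elsewhere in the ring, would behave like phenyl or like pyridin-2-yl. Also open, going by these compounds, is whether a chlorophenyl or a non-aromatic cyclohexyl group would keep this level.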